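A Second Chlorine on a Compound at the Limit

The compounds below may be only part of what the source reports. "The series", "measured", "known", "first", "only" and "open" are said of these compounds alone.

In a functional assay on NIH3T3 cells (Mus musculus) (a higher number here means that more compound is needed for the effect, a lower number that less compound is needed), compound 3 (`O=C(N[C@@H]1[C@H](O)[C@@H](CO)O[C@H]1n1cnc2c(NCc3cc(O)cc4ccccc34)ncnc21)c1cccc(Cl)c1`) gives > 50 uM, which is a limit and not a number. Compound 2 (`O=C(N[C@@H]1[C@H](O)[C@@H](CO)O[C@H]1n1cnc2c(NCc3cccc4ccccc34)ncnc21)c1cc(O)cc(O)c1`) likewise gives only a limit, > 50 uM. Compound 1 (`O=C(N[C@@H]1[C@H](O)[C@@H](CO)O[C@H]1n1cnc2c(NCc3cccc4ccccc34)ncnc21)c1cc(Cl)cc(Cl)c1`) gives a true number, 35 uM. Compound 4 (`O=C(N[C@@H]1[C@H](O)[C@@H](CO)O[C@H]1n1cnc2c(NCc3cc(O)cc4ccccc34)ncnc21)c1cc(Cl)cc(Cl)c1`) follows from compound 3 by chloro in place of hydrogen on an aromatic carbon, turning 3-chlorophenyl into the 3,5-dichlorophenyl of compound 1. Going by the values given here, one measured step touches that group: an at least 1.4-fold higher number from compound 1 to compound 2 (0.15 log units; that floor lies within the scatter). Its floor stays within the scatter, so it offers only weak support for favouring the dichlorophenyl. A small fall in the number is therefore expected, possibly none beyond the scatter. The expected change is an at least 1.2-fold lower number from compound 3 to compound 4 (0.09 log units; that floor lies within the scatter). For compound 4 the estimate is 40 uM, with an expected range from 20 uM to 80 uM.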

Compound 4, concentration for half-maximal effect: 43 uM
Beside the measured number, compound 4's estimate is 1.1-fold (0.03 log units) below it; low and high end bracket the measured number.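

On the 3-chlorophenyl, chloro in place of hydrogen turns a limit into a true number in this assay, giving an at least 1.1-fold lower number from compound 3 to compound 4 (0.06 log units; that floor lies within the scatter). That step can be read only as a floor because compound 3 sits at a limit: the limit of > 50 uM in this assay, at which 2 of the 4 values shown sit. With the 3,5-dichlorophenyl present in both compounds, hydroxy in place of hydrogen gives a 1.2-fold higher number from compound 1 to compound 4 (0.09 log units; within the scatter), so the two values cannot be told apart.

Going by these compounds, whether the second chlorine lowers the number beyond the scatter stays open. Also open, on these data alone, is how an amine or a carboxylic acid would compare with chloro at this position.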